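The source may report more compounds than this note shows. Statements on the series, on what has been measured and on what is new or still open speak of the compounds shown alone.

Compound 1 `CCOC(=O)CCCCCOc1cccc(CN(C(=O)c2ccc(-c3cccc(N(C)C)c3)cc2)C(C)C)c1` gives in an ADME assay on Raji cells (Homo sapiens) for cytotoxicity, read by CellTiter-Glo and resazurin assay, with a stated time of 72 h (a lower number here means that less compound is needed, a higher number that more compound is needed for the effect), a result that is a limit of the assay, > 26000 nM. Compound 2 `CCOC(=O)CCCCCOc1cccc(CN(C(=O)c2ccc(-c3cccc4ccccc34)cc2)C(C)C)c1` gives in this assay likewise only a limit, > 26000 nM. Compound 3 `CCOC(=O)CCCCCOc1cccc(CN(C(=O)c2ccc(-c3cccc(C(C)=O)c3)cc2)C(C)C)c1` gives in this assay again only a limit, > 26000 nM.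

Compound 3 thus stands where every measured compound of this set stands, at the limit of > 26000 nM in this assay, at which 3 of the 3 values shown sit, and no number can be placed below it. The steps that lead to it, a step that the two limits leave unreadable from compound 1 to compound 3 and a step that the two limits leave unreadable from compound 2 to compound 3, are both hidden, as is a step that the two limits leave unreadable from compound 1 to compound 2; none of the three shows whether exchanging the group on the aromatic carbon moves the read-out at all.

The unmeasured compound 4 `CCOC(=O)CCCCCOc1cccc(CN(C(=O)c2ccc(-c3cccc(OCc4ccccc4)c3)cc2)C(C)C)c1` differs from compound 3 in one place: benzyloxy in place of acetyl on an aromatic carbon. All three measured steps in this assay are unreadable, so no step size can be drawn from them, and nothing measured here shows that any of these groups shifts the read-out. The chemist accordingly expects no step beyond the scatter, a step that the limit leaves unreadable from compound 3 to compound 4, and expects compound 4 to sit at the limit as well. The estimate for compound 4 in this assay is 30000 nM, with a range from 10000 nM to 100000 nM.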

Compound 4, half-maximal effective concentration: > 26000 nM
Compound 4: only a limit was reported (the forecaster's own chance of this, stated with the estimate: 85%); the middle value does not contradict the limit.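

Compound 4 gives only a limit in this assay, as do compound 1 and compound 3, so neither the change from compound 3 to compound 4 nor that from compound 1 to compound 4 can be read as a step: the limit of > 26000 nM in this assay, at which 4 of the 4 values shown sit.

The compounds shown leave open whether exchanging the group on the aromatic carbon moves the read-out at all, and where any of the four compounds would stand on a measured number.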